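This account rests on a few compounds, and the source may have more. Where it says the series, first, only, none or still open, it means among the compounds named here.

Compound 2 `CCCC/N=C1/SC[C@H]2[C@H](O)[C@@H](O)[C@H](CO)N12` in an assay for inhibition of beta-galactosidase (Bos taurus), read by spectrophotometry (a lower number here means a stronger inhibitor, a higher number a weaker inhibitor), gives 719000 nM, the highest of the three numbers recorded, though its gap to the nearest neighbour lies within the scatter. That neighbour is compound 1 `CCCCCCCCNC(=S)N1[C@H](CO)[C@@H](O)[C@H](O)[C@H]1CO`, which in this assay gives 414000 nM. Compound 3 `CCCCCCCCNC(=S)N1[C@@H](CO)[C@H](O)[C@@H](O)[C@@H]1CO` is the mirror image of compound 1, and in this assay compound 3 gives 266000 nM; the gap from compound 2 to compound 3 lies beyond the scatter. Going by the values given here, the only step between two compounds differing in one place is a 1.6-fold lower number from compound 1 to compound 3 (0.19 log units; within the scatter), and what sets those two apart is the fact that compounds 1 and 3 differ only in the configuration as drawn.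

Compound 4 `CCCCCC/N=C1/SC[C@H]2[C@H](O)[C@@H](O)[C@H](CO)N12` differs from compound 2 by ethyl in place of hydrogen on a saturated chain carbon, four bonds along the chain from a double-bonded nitrogen. Among the compounds with values here, no measured step bears on this change: the one step recorded concerns configuration alone, and the chain of compound 1 differs from that of compound 2 together with a different core, so no single-place comparison exists for chain length. There is thus no measured ground for a direction, and the expectation in this assay is a step of a 1.3-fold lower number from compound 2 to compound 4 (0.12 log units; within the scatter) that stays within the scatter. The estimate for compound 4 in this assay is 550000 nM, expected to fall between 200000 nM and 1400000 nM.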

Compound 4, half-maximal inhibitory concentration: 599000 nM
The estimate for compound 4 lay 1.1-fold (0.04 log units) below the measured number; the range from low to high includes it.
By their numbers in this assay, from the lowest: compounds 3, 1, 4 and 2 (each within the scatter of the next, the first and the last beyond it).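

In this assay, ethyl in place of hydrogen on a saturated chain carbon, four bonds along the chain from a double-bonded nitrogen, gives a 1.2-fold lower number from compound 2 to compound 4 (0.08 log units; within the scatter), so compound 2 and compound 4 cannot be told apart in this measurement. Going by these compounds alone, this is the first comparison where the chain alone differs on an unchanged core, and it shows that, at this place, a chain with two more carbons makes no difference that stands out from the ordinary spread of repeat measurements. Within the data shown here, the only recorded evidence concerns mirror-image configuration and says nothing about a change in chain length, so no cause can be offered for this result.

One step on one core cannot show how the number would respond to a much longer chain, such as decyl, or to a different kind of group at this place, such as an amine or a carboxylic acid. The mirror image of compound 4 is also missing from the compounds shown, so it remains open whether configuration matters any more on this core than it does between compound 1 and compound 3.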